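The source may hold more compounds than are shown below. What is called first, only, known or untested is meant among the compounds shown, and "the series" means these compounds.

Measured so far in a functional assay on MKN-74 cells (Homo sapiens) for antiproliferative activity, with a stated time of 24 h; on this read-out higher numbers stand for weaker inhibition and lower numbers for stronger inhibition:
compound 1 `NC(=O)c1c(NC(=O)c2ccccc2Cl)sc2c1CCN(Cc1ccccc1Cl)C2`, 4430 nM
compound 2 `COc1ccc(NC(=S)N2CCc3c(sc(NC(=O)c4ccccc4Cl)c3C(N)=O)C2)cc1`, 19600 nM
compound 3 `NC(=O)c1c(NC(=O)c2ccccc2)sc2c1CCN(C(=S)Nc1ccccc1Cl)C2`, 11800 nM

Compound 3 stands second highest of the three numbers; compound 2 is its nearest neighbour, compound 1 lies furthest from it. Within the data shown here, the only single-point step measured in this assay, a 4.4-fold higher number from compound 1 to compound 2 (0.65 log units; beyond the scatter), concerns the substituent on the ring amine nitrogen and leaves the benzoyl ring untouched.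

Compound 4 `CSc1ccccc1C(=O)Nc1sc2c(c1C(N)=O)CCN(C(=S)Nc1ccccc1Cl)C2` differs from compound 3 by methylsulfanyl in place of hydrogen on an aromatic carbon. Among the measured compounds shown here, no measured pair differs at the benzoyl ring alone: compound 1 and compound 3 differ in two places at once, so their values in this assay give no isolated reading of a benzoyl substituent. Nothing in the series therefore bears on the step from compound 3 to compound 4, and the expectation is a step of no clear size beyond the scatter, no change at the digits printed from compound 3 to compound 4 (within the scatter). With compound 3 as the only anchor, compound 4 is expected to give about 11800 nM in this assay, estimated within 4000 nM to 35000 nM.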

Compound 4, half-maximal inhibitory concentration: 6550 nM
For compound 4 the middle estimate is 1.8-fold (0.26 log units) above the measured one, within the range that was stated.
By their numbers in this assay, from the lowest: compounds 1, 4, 3 and 2 (each within the scatter of the next, the first and the last beyond it).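

Methylsulfanyl in place of hydrogen on an aromatic carbon, ortho to a large group, gives a 1.8-fold lower number from compound 3 to compound 4 (0.26 log units; within the scatter) in this assay. Among these compounds, this is the first reading at the benzoyl ring alone, with the group on the ring amine nitrogen unchanged, and it shows that this position takes methylsulfanyl with no change that stands clear of the scatter. No supporting measurement bears on this result.

Still open, on these data alone, is whether an amine, a carboxylic acid or a longer chain such as butylsulfanyl at this position would give a step beyond the scatter. Also open, as far as these compounds go, is how the chlorine on the benzoyl ring compares with hydrogen or methylsulfanyl, since compound 1 and compound 2 each differ from compound 3 and compound 4 in more than one place.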